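The compounds below may be only part of what the source reports. "The series", "measured", "known", "first", "only" and "open" are said of these compounds alone.

Compound 1, `O=C(CCl)Nc1ccc(Cn2nc(-c3ccc(Oc4ccccc4)cc3)cc2CO)cc1`, is one of three compounds tested in a functional assay on JeKo-1 cells (Homo sapiens) for inhibition, read by luminescence and CellTiter-Glo, with a stated time of 72 h; a lower number here means a stronger inhibitor, a higher number a weaker inhibitor. In this assay compound 1 gives 400 nM, the lowest of the two plain numbers recorded. Compound 2, `CCOC(=O)c1cc(-c2ccc(Oc3ccccc3)cc2)nn1C1CCCN(C(=O)CCl)C1`, carries an ethoxycarbonyl on the shared core and a different chain on its ring nitrogen; in this assay compound 2 gives 800 nM, a value that sits within the usual scatter of the number for compound 1. Compound 3, `C/C=C/C(=O)N1CCCC(n2nc(-c3ccc(Oc4ccccc4)cc3)cc2CO)C1`, has only a limit: in this assay compound 3 gives > 60000 nM, which is a limit of the assay and not a number (the limit of > 60000 nM in this assay, at which 1 of the 3 values shown sits).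

Compound 4, `CCOC(=O)c1cc(-c2ccc(Oc3ccccc3)cc2)nn1Cc1ccc(NC(=O)CCl)cc1`, is still to be measured in this assay. The change from compound 1 is ethoxycarbonyl in place of hydroxymethyl on an aromatic carbon, in words: ethoxycarbonyl in place of hydroxymethyl on an aromatic carbon. For the measured compounds named here, no measured pair differs in this single place. Compound 2, with the same ethoxycarbonyl, gives 800 nM, which is close to the number for compound 1, so the change is expected to bring no step beyond the scatter, a 1.3-fold higher number from compound 1 to compound 4 (0.10 log units; within the scatter). Compound 4 is therefore expected to give about 500 nM, with a likely range from 150 nM to 1600 nM.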

Compound 4, half-maximal inhibitory concentration: 400 nM
Estimate against measurement, compound 4: 1.3-fold (0.10 log units) above; measured number inside the range.
By their numbers in this assay, from the lowest: compounds 1, 4 and 2 (each within the scatter of the next). At a limit, above all of these: compound 3.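

In this assay, replacing hydroxymethyl with ethoxycarbonyl on this aromatic carbon of the five-membered aromatic ring gives no change at the digits printed from compound 1 to compound 4 (within the scatter). This is the first pair among the compounds shown that differs in this one place alone, so the change can now be read directly and does not have to be inferred from compound 2, which also differs from compound 1 in the chain on its ring nitrogen. At this position, a group of 5 heavy atoms with 0 hydrogen-bond donors stands in for one of 2 heavy atoms with 1 hydrogen-bond donor without a step beyond the scatter, and nothing measured here offers a reason for this result.

The compounds shown leave open whether a carboxylic acid, an amine or a longer ester chain on this same carbon would also leave the number within the scatter. A single pair also cannot tell whether this change would behave the same way alongside the other ring-nitrogen chains, those of compound 2 and compound 3.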